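The compounds below may be only part of what the source reports. "The series", "measured", "known", "first", "only" and "open" are said of these compounds alone.

- compound 1 `CCSc1ccc(C2C(Oc3ccccc3)C(=O)N2c2cc(OC)c(OC)c(OC)c2)cc1`: 632 nM
- compound 2 `CCOc1ccc(C2C(C3CC3)C(=O)N2c2cc(OC)c(OC)c(OC)c2)cc1`: 63 nM
- compound 3 `C=CC1C(=O)N(c2cc(OC)c(OC)c(OC)c2)C1c1ccc(SC)cc1`: 113 nM

All three values come from a functional assay on HT-29 cells (Homo sapiens) for inhibition, read by sulforhodamine B assay, with a stated time of 72 h; on this read-out lower numbers stand for stronger inhibition and higher numbers for weaker inhibition. Compound 1 has the highest of the three numbers, so it is the weakest inhibitor here, and its distance to each of the other two lies beyond the usual scatter.

The next compound to consider is compound 4 `CCSc1ccc(C2CC(=O)N2c2cc(OC)c(OC)c(OC)c2)cc1`, which is compound 1 with one change: hydrogen in place of phenoxy on a saturated ring carbon. In words, hydrogen stands in place of phenoxy on a saturated ring carbon, and the 4-(ethylsulfanyl)phenyl group stays.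

Among the compounds with values here, no measured pair here differs in only one place, so no clean step is available as a guide. The hints are indirect. At that same ring carbon, compound 2 at 63 nM carries a cyclopropyl group and compound 3 at 113 nM carries a vinyl group, while both also differ from compound 1 elsewhere. As far as these compounds go, neither has hydrogen there, so what bare hydrogen does remains untested.

With those two values in mind, a move towards a lower number seems more likely than a move towards a higher one. The expected change is a 2.5-fold lower number from compound 1 to compound 4 (0.40 log units; beyond the scatter), and this estimate is loose. For compound 4 the estimated value is 250 nM, with an expected range from 60 nM to 1000 nM.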

Compound 4, half-maximal inhibitory concentration: 311 nM
The estimate for compound 4 lay 1.2-fold (0.09 log units) below the measured number, within the range that was stated.
By their numbers in this assay, from the lowest: compounds 2 and 3 (each within the scatter of the next); then compound 4; then compound 1.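

In this assay, within the data shown here, putting bare hydrogen in place of phenoxy on the saturated ring carbon gives a 2.0-fold lower number from compound 1 to compound 4 (0.31 log units; beyond the scatter) and provides the first comparison here in which only one place changes. The step is modest but lies beyond the scatter, and it shows that the phenoxy group is not required at this position: with no group at all on that carbon, the compound still inhibits, and its number is lower than with phenoxy attached. Nothing available explains this shift, so it stands as an observation without a known cause.

One open question is whether a group on this carbon can bring the number lower than hydrogen does while the 4-(ethylsulfanyl)phenyl group stays in place, as a methyl, a hydroxyl or an amine might test. It is also unclear whether the higher number with phenoxy goes with its aromatic ring or with the oxygen that links the ring to the core, which a methoxy or a benzyl group at the same carbon could help separate.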